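Replacing Ethynyl with 3-(Trifluoromethyl)phenyl in Compound 2

This account rests on a few compounds, and the source may have more. Where it says the series, first, only, none or still open, it means among the compounds named here.

Three compounds built on one shared core have been run in a functional assay on SK-OV-3 cells (Homo sapiens) for antiproliferative activity, read by MTT assay, with a stated time of 72 h; a higher number here means a weaker inhibitor, a lower number a stronger inhibitor. Compound 1 `C#Cc1ccc(NC(=O)CCc2cccc3c2B(O)OC3)cc1` gives 6300 nM in this assay, compound 3 `Cc1cc(C)c(NC(=O)CCc2cccc3c2B(O)OC3)c(C)c1` gives 19000 nM, and compound 2 `C#Cc1cccc(NC(=O)CCc2cccc3c2B(O)OC3)c1` gives 980 nM, the lowest number of the three; its gaps to compound 1 and to compound 3 both lie beyond the scatter, so compound 2 is the strongest inhibitor among them. No two of these compounds differ in only one place, so no single structural step can be isolated from the measured set.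

Compound 4 `O=C(CCc1cccc2c1B(O)OC2)Nc1cccc(-c2cccc(C(F)(F)F)c2)c1` has not yet been measured. It departs from compound 2 at one point: 3-(trifluoromethyl)phenyl in place of ethynyl on an aromatic carbon. Compound 1 and compound 3 carry other substituents and give higher numbers, but neither differs from compound 2 in one place only, so the direction of this change is open. A moderate loss is expected, the estimate for compound 4 being 2500 nM with a range from 600 nM to 10000 nM. The expected step is a 2.6-fold higher number from compound 2 to compound 4 (0.41 log units; beyond the scatter).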

Compound 4, half-maximal inhibitory concentration: 390 nM
For compound 4 the middle estimate is 6.4-fold (0.81 log units) above the measured one, and the stated range ends above it.
By their numbers in this assay, from the lowest: compound 4; then compound 2; then compound 1; then compound 3.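

In this assay the exchange of ethynyl for 3-(trifluoromethyl)phenyl gives a 2.5-fold lower number from compound 2 to compound 4 (0.40 log units; beyond the scatter) and makes compound 4 the strongest inhibitor of the four, since all its gaps to the others that can be read lie on the lower side. Among the compounds shown here, this is the first step in the set that changes one place only, and it shows that this aromatic carbon, meta to a large group, accepts a much larger substituent carrying an aromatic ring of its own with a modest gain rather than a loss. Nothing measured here speaks to the reason for that gain.

The compounds shown do not separate the contribution of the added phenyl ring from that of the trifluoromethyl group, as a plain phenyl would. Nor do they tell how an amine or a carboxylic acid on that ring would fare.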